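The source may hold more compounds than are shown below. What is called first, only, known or untested is meant among the compounds shown, and "the series" means these compounds.

Compounds measured in an assay on isolated protein for antagonist activity at Rap guanine nucleotide exchange factor 4 (Homo sapiens), read by fluorescence and cAMP accumulation; on this read-out higher numbers stand for weaker inhibition and lower numbers for stronger inhibition:

compound 1, `CCc1cccn1S(=O)(=O)c1ccc(OC)cc1`: 8000 nM
compound 2, `COC(=O)c1ccc2c(ccn2S(=O)(=O)c2c(C)cc(C)cc2C)c1`: > 300000 nM

The two values fall far apart. Compound 1 gives a number. Compound 2 gives only a limit of the assay, > 300000 nM, and not a number (the limit of > 300000 nM in this assay, at which 1 of the 2 values shown sits). Of the two, compound 2 therefore stands at the upper end of the numbers shown, with no exact figure to place it.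

The next compound, compound 3 (`Cc1cc(C)c(S(=O)(=O)n2ccc3cc(C(=O)O)ccc32)c(C)c1`), differs from compound 2 in one place: hydrogen in place of methyl on an oxygen next to a carbonyl group. Among the measured compounds shown here, no pair of measured compounds shares this change, so there is no recorded step to lean on. Compound 2 already sits at the limit > 300000 nM in this assay, and the change is not expected to move the reading away from that limit in a way the assay could resolve. Compound 3 is therefore expected to come in at 300000 nM, within 100000 nM to 1000000 nM, most likely reported as a limit again. The expected step is a number no higher from compound 2 to compound 3 (the limit leaves the size open), nothing beyond the scatter.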

Compound 3, half-maximal inhibitory concentration: 10800 nM
Beside the measured number, compound 3's estimate is 28-fold (1.44 log units) above it; the whole stated range lies above it.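

In this assay, going from methoxycarbonyl to carboxy gives an at least 27-fold lower number from compound 2 to compound 3 (1.44 log units; beyond the scatter). Among the compounds shown here, this is the first single change recorded, and it shows that this position on the shared core is not indifferent: with the rest of the structure untouched, removing one methyl from an oxygen next to a carbonyl group separates a compound that reaches a number from one that does not. The value of compound 2 is a limit of the assay and not a number, so the full size of the step stays open at one end: the limit of > 300000 nM in this assay, at which 1 of the 3 values shown sits.

The compounds shown do not tell whether the lower number depends on the carboxy group itself or only on the methyl leaving, a question that a primary amide or a hydroxymethyl group at the same place would help to answer. As far as these compounds go, compound 1 differs from compound 2 and compound 3 in more than one place, so how its ethyl and methoxy groups relate to this change remains open.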